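The source may hold more compounds than are shown below. What is called first, only, known or untested is meant among the compounds shown, and "the series" means these compounds.

Of the compounds shown here, three have so far been tested in a functional assay on MDA-MB-231 cells (Homo sapiens) for cytotoxicity, read by MTT assay, with a stated time of 48 h (on this read-out lower numbers stand for stronger inhibition and higher numbers for weaker inhibition), and none of them gave a number. For the measured compounds named here, compound 1 `O=c1ccoc2cc(OCc3cn(Cc4cccc(F)c4)nn3)ccc12` is the first of them; in this assay compound 1 reaches only the limit of measurement, > 100000 nM. Compound 2 `O=c1ccoc2cc(OCc3cn(Cc4cccc(Br)c4)nn3)ccc12` is its close relative, with bromo in place of fluoro on an aromatic carbon; in this assay compound 2 likewise stops at the limit, > 100000 nM. Because both values are limits, the step that the two limits leave unreadable from compound 1 to compound 2 cannot be read. Compound 3 `C#CCOc1ccc2c(=O)ccoc2c1` is a smaller compound that keeps the shared core; in this assay compound 3 also stops at the limit, > 100000 nM. So compound 2 stands exactly where every tested compound stands, described by the limit of > 100000 nM in this assay, at which 3 of the 3 values shown sit.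

The next compound, compound 4 `O=c1ccoc2cc(OCc3cn(Cc4ccc(Br)cc4)nn3)ccc12`, is built from the same atoms as compound 2, joined differently: 4-bromophenyl in place of 3-bromophenyl on a saturated chain carbon bound to an aromatic nitrogen. Going by the values given here, no measured step bears on this kind of rearrangement, and the one step available is unreadable, so nothing here points toward either stronger or weaker inhibition. The step from compound 2 to compound 4 is therefore expected to be a number no higher from compound 2 to compound 4 (the limit leaves the size open), with a limit the most likely outcome. For compound 4 the estimate is 100000 nM, within a range from 20000 nM to 300000 nM.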

Compound 4, half-maximal inhibitory concentration: > 100000 nM
Compound 4: a limit, no number (the forecaster's own chance of this, stated with the estimate: 80%); the middle value sits exactly at the limit.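

Compound 4 also gives a limit and not a number, so the steps to it from compound 1 and from compound 2 cannot be read, and all the compounds shown share one description: the limit of > 100000 nM in this assay, at which 4 of the 4 values shown sit.

The compounds shown leave open whether in this assay any group on the shared core gives a measurable number.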